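From methoxy to tert-butyl on the aromatic ring

A few compounds are considered here, and "the series" means these few. Any claim that something is new, unique, unknown or untested is made for them only; others in the source may bear on it.

In a functional assay on HL-60 cells (Homo sapiens) for antiproliferative activity, read by MTT assay, with a stated time of 72 h (on this read-out lower numbers stand for stronger inhibition and higher numbers for weaker inhibition), compound 1 (`COc1ccc(OCCCON2C(N)=NC(N)=NC23CCOCC3)cc1`) gives 1670 nM and compound 2 (`NC1=NC2(CCOCC2)N(OCCCOc2ccc(Cl)c(Cl)c2)C(N)=N1`) gives 1240 nM, which places both at the upper end of the three numbers. Compound 3 (`NC1=NC2(CCOCC2)N(OCCCOc2ccccc2Br)C(N)=N1`) gives 610 nM. Compound 4 (`CC(C)(C)c1ccc(OCCCON2C(N)=NC(N)=NC23CCOCC3)cc1`) carries tert-butyl in place of methoxy on an aromatic carbon, para to a large group: tert-butyl in place of methoxy on an aromatic carbon. Among the measured compounds shown here, two measured steps bear on this change. Swapping the whole 4-methoxyphenyl gave a 1.3-fold lower number from compound 1 to compound 2 (0.13 log units; within the scatter) with 3,4-dichlorophenyl and a 2.7-fold lower number from compound 1 to compound 3 (0.44 log units; beyond the scatter) with 2-bromophenyl. For the measured compounds named here, no measured compound carries tert-butyl, so only a small step toward a lower number, possibly none beyond the scatter, is expected in this assay. The expected change is a 1.7-fold lower number from compound 1 to compound 4 (0.22 log units; within the scatter). Compound 4 is estimated at 1000 nM, within an expected range of 400 nM to 2400 nM.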

Compound 4, half-maximal inhibitory concentration: 870 nM
For compound 4 the middle estimate is 1.1-fold (0.06 log units) above the measured one; measured number inside the range.
By their numbers in this assay, from the lowest: compounds 3, 4, 2 and 1 (each within the scatter of the next, the first and the last beyond it).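

In this assay, among the compounds shown here, the earlier steps swapped the whole 4-methoxyphenyl, whereas this one changes only the group on the aromatic carbon, para to a large group: tert-butyl in place of methoxy gives a 1.9-fold lower number from compound 1 to compound 4 (0.28 log units; within the scatter). At this position, then, a group of 4 heavy atoms with no hydrogen-bond acceptor stands in for one of 2 heavy atoms with one acceptor, without a step beyond the scatter. Nothing available explains this step. The compounds shown leave open whether an amine or a carboxylic acid on this same carbon would give a step beyond the scatter.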